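The source may report more compounds than this note shows. Statements on the series, on what has been measured and on what is new or still open speak of the compounds shown alone.

Working notes on the series. Compound 1 `O=C(CN1CCN(c2nnc(Cc3ccncc3)c3ccccc23)CC1)Nc1cccc(Br)c1` is one of two compounds with a number in a functional assay on A549 cells (Homo sapiens) for cytotoxicity, read by MTT assay, with a stated time of 72 h; on this read-out lower numbers stand for stronger inhibition and higher numbers for weaker inhibition. In this assay compound 1 gives 1530 nM, the lowest of the two values on hand. Going by the values given here, compound 2 `O=C(CN1CCN(c2nnc(Cc3ccccc3)c3ccccc23)CC1)Nc1cc(C(F)(F)F)ccc1Cl` is the only other measured member; in this assay compound 2 gives 89000 nM, a far higher number that lies well beyond the scatter of repeated runs, but compound 2 differs from compound 1 in more than one place, so the two values show only that the pair sit far apart and no single step can be read out of them.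

Compound 3 `Cc1ccccc1NC(=O)CN1CCN(c2nnc(Cc3ccncc3)c3ccccc23)CC1` is not yet measured. It differs from compound 1 in one place, (2-methylphenyl in place of 3-bromophenyl on an amide-type nitrogen). Among the compounds with values here, no measured pair isolates such a change on the amide-type nitrogen, so there is no step on hand to anchor an expectation. The step from compound 1 to compound 3 is expected to be a 2.0-fold higher number from compound 1 to compound 3 (0.29 log units; within the scatter), a small loss that may fall within the scatter. Compound 3 is estimated at 3000 nM in this assay, with a range from 800 nM to 12000 nM.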

Compound 3, half-maximal inhibitory concentration: 43100 nM
The estimate for compound 3 lay 14-fold (1.16 log units) below the measured number; the whole stated range lies below it.
By their numbers in this assay, from the lowest: compound 1; then compound 3; then compound 2.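

Going by these compounds alone, the step of a 28-fold higher number from compound 1 to compound 3 (1.45 log units; beyond the scatter) is the first single-place reading, and it shows that in this assay the aryl group on the amide-type nitrogen strongly affects the read-out. The two groups have the same heavy-atom count and the same zero counts of hydrogen-bond donors and acceptors, yet 2-methylphenyl in place of 3-bromophenyl moves the number far beyond the scatter, although the swap changes both the substituent and where it sits, so this one step cannot separate the loss of the bromine from the gain of the methyl or from the shift in placement. No measurement on hand bears on why this step is so large.

The compounds shown leave open whether the lower number of compound 1 depends on the bromine at all, or whether an unsubstituted phenyl or a chlorophenyl on the same nitrogen would read close to it. Also open, going by these compounds, is how an amine or a carboxylic acid on this phenyl group would read in this assay.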